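Benzyl for 5-chlorothiophen-2-yl on the methylated compound

The source may hold more compounds than are shown below. What is called first, only, known or untested is meant among the compounds shown, and "the series" means these compounds.

Going by the values given here, in a functional assay (Platelet, plasma) for inhibition, with Homo sapiens as the target (a lower number here means a stronger inhibitor, a higher number a weaker inhibitor), compound 2 (`N#Cc1cc2c(nc1N1CCC(C(=O)NS(=O)(=O)c3ccc(Cl)s3)CC1)COC2=O`) gives 4470 nM, and it is the only compound so far with a true number. Compound 3 (`CC1OC(=O)c2cc(C#N)c(N3CCC(C(=O)NS(=O)(=O)c4ccc(Cl)s4)CC3)nc21`) gives only a limit, > 300000 nM. Among the compounds with values here, the one measured step, an at least 67-fold higher number from compound 2 to compound 3 (1.82 log units; beyond the scatter), comes with methyl in place of hydrogen on a saturated ring carbon, and its size is itself bounded by that limit. The readings in this assay thus end at the limit of > 300000 nM in this assay, at which 2 of the 3 values shown sit.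

Compound 4 (`CC1OC(=O)c2cc(C#N)c(N3CCC(C(=O)NS(=O)(=O)Cc4ccccc4)CC3)nc21`) keeps that methyl and differs from compound 3 by benzyl in place of 5-chlorothiophen-2-yl on a sulfonyl sulfur, which is benzyl in place of 5-chlorothiophen-2-yl on a sulfonyl sulfur. Within the data shown here, no measured step isolates this swap. Among the measured compounds shown here, the only measured compound with benzyl on the sulfonyl sulfur is compound 1 (`N#Cc1cc2c(nc1N1CCC(C(=O)NS(=O)(=O)Cc3ccccc3)CC1)CNC2=O`), and its > 300000 nM is also a limit. Neither compound 1 nor compound 3 therefore offers a number from which a gain or a loss could be read.

The expected change is a number no higher from compound 3 to compound 4 (the limit leaves the size open), with nothing beyond the scatter anticipated in either direction. The estimate for compound 4 is 300000 nM, with an expected range from 100000 nM to 500000 nM, and the result will most probably be reported only as a limit.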

Compound 4, half-maximal inhibitory concentration: > 300000 nM
Compound 4 ended at the assay's limit; the forecaster's own chance of this, stated with the estimate: 85%; the middle value lies on the limit itself.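

Compound 3 and compound 4 both give only limits in this assay, so no step can be read from compound 3 to compound 4. The readings in the series end at one value: the limit of > 300000 nM in this assay, at which 3 of the 4 values shown sit.

The compounds shown leave open whether benzyl or 5-chlorothiophen-2-yl on the sulfonyl sulfur gives the lower number on the methylated core.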